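The compounds below may be only part of what the source reports. "The series", "measured", "known", "first", "only" and "open" are said of these compounds alone.

For the measured compounds named here, in a functional assay on CRL2813 cells (Homo sapiens) for cytotoxicity, read by sulforhodamine B assay, with a stated time of 5 days (on this read-out higher numbers stand for weaker inhibition and lower numbers for stronger inhibition), compound 3 `COc1cccc(NC(=O)N[C@H]2CC[C@H](Oc3ccc(F)cc3)CC2)c1` gives 14000 nM, the only number reported among the three measured compounds. For compound 1 `O=C(Nc1ccc(Br)cc1)N[C@H]1CC[C@H](Oc2ccc(F)cc2)CC1` the result is a limit, > 20000 nM. For compound 2 `CSc1ccc(NC(=O)N[C@H]2CC[C@H](Oc3ccc(F)cc3)CC2)cc1` the result is likewise a limit, > 20000 nM. Compound 4 `O=C(Nc1ccccc1Br)N[C@H]1CC[C@H](Oc2ccc(F)cc2)CC1` differs from compound 3 by 2-bromophenyl in place of 3-methoxyphenyl on an amide-type nitrogen. The measured steps that bear on this are an at least 1.4-fold lower number from compound 1 to compound 3 (0.15 log units; that floor lies within the scatter) and an at least 1.4-fold lower number from compound 2 to compound 3 (0.15 log units; that floor lies within the scatter); both are floors lying within the scatter, and both run toward methoxyphenyl, whereas here a bromo group enters. Compound 4 is therefore expected to show a 1.4-fold higher number from compound 3 to compound 4 (0.15 log units; within the scatter) in this assay. Compound 4 is estimated at 20000 nM, between 8000 nM and 40000 nM, with a fair chance that only a limit is reported.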

Compound 4, half-maximal inhibitory concentration: 7700 nM
Compound 4: the middle estimate sits 2.6-fold (0.41 log units) above what was measured; the measured number lies below the stated range.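

For the compounds shown here, on the amide-type nitrogen, 2-bromophenyl gives the first steps beyond the scatter in this assay, with an at least 2.5-fold lower number from compound 1 to compound 4 (0.41 log units; beyond the scatter) and an at least 2.5-fold lower number from compound 2 to compound 4 (0.41 log units; beyond the scatter). A bromo group therefore does not by itself keep the number at the limit, since 2-bromophenyl and 4-bromophenyl part here, and the methoxy group is not needed for a measurable number, although a 1.8-fold lower number from compound 3 to compound 4 (0.26 log units; within the scatter) stays within the scatter. From the compounds shown here alone, both larger steps are only floors, and the true size stays unknown: the limit of > 20000 nM in this assay, at which 2 of the 4 values shown sit. The compounds shown leave open whether an amine or a carboxylic acid on this aromatic ring would lower the number further.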